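The source may report more compounds than this note shows. Statements on the series, on what has been measured and on what is new or still open speak of the compounds shown alone.

Compound 1 `Cc1ccc(NS(=O)(=O)c2cccc(CCCCCCNC(=O)/C=C/c3cccnc3)c2)cc1` gives 2.98 nM
Compound 2 `Cc1ccc(C)c(NS(=O)(=O)c2cccc(CCCCCCNC(=O)/C=C/c3cccnc3)c2)c1` gives 0.84 nM

Both numbers come from a functional assay on K562 cells (Homo sapiens) for inhibition, read by CCK-8 assay, with a stated time of 72 h (a higher number here means a weaker inhibitor, a lower number a stronger inhibitor), and compound 2 holds the lower of the two, with compound 1 as its nearest neighbour. Compound 3 `CCc1ccc(NS(=O)(=O)c2cccc(CCCCCCNC(=O)/C=C/c3cccnc3)c2)cc1` has not yet been measured. It differs from compound 2 as follows: 4-ethylphenyl in place of 2,5-dimethylphenyl on a sulfonamide nitrogen. In words, 4-ethylphenyl stands in place of 2,5-dimethylphenyl on a sulfonamide nitrogen.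

Among the compounds with values here, only one measured step bears on this change. It is a 3.5-fold lower number from compound 1 to compound 2 (0.55 log units; beyond the scatter), a modest move beyond the scatter, made when 2,5-dimethylphenyl replaced 4-methylphenyl on the same nitrogen. The 4-ethylphenyl of compound 3 resembles the 4-methylphenyl of compound 1 more closely than the group it replaces, so a move of similar size in the opposite direction is expected. Within the data shown here, no measured pair shows what ethyl does in place of methyl, so the uncertainty stays wide. The expected change is a 3.3-fold higher number from compound 2 to compound 3 (0.52 log units; beyond the scatter). For compound 3 the estimated value is 2.8 nM, with an expected range from 1 nM to 8 nM.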

Compound 3, half-maximal inhibitory concentration: 3.89 nM
For compound 3 the middle estimate is 1.4-fold (0.14 log units) below the measured one; the range from low to high includes it.
By their numbers in this assay, from the lowest: compound 2; then compounds 1 and 3 (each within the scatter of the next).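

In this assay, the 4-ethylphenyl and 2,5-dimethylphenyl groups on the sulfonamide nitrogen hold the same atoms, joined differently, yet the step between them is a 4.6-fold higher number from compound 2 to compound 3 (0.67 log units; beyond the scatter) and lies beyond the scatter, so at this position the arrangement of those carbons matters and not just their count. Lengthening the methyl of the 4-methylphenyl group to the ethyl of the 4-ethylphenyl group gives a 1.3-fold higher number from compound 1 to compound 3 (0.12 log units; within the scatter) and so does not separate the two, which means that among these three compounds, the lower number belongs to the 2,5-dimethylphenyl group alone, while the two groups with a single chain on the ring stay together. Nothing available here explains why the arrangement of these carbons should matter.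

Going by these compounds, what remains open is whether both methyl groups of the 2,5-dimethylphenyl are needed for the lower number, or whether one of them would do. Also open, on these data alone, is how a plain phenyl, a chlorophenyl or a methoxyphenyl on the same nitrogen would read in this assay, and whether a propyl in place of the ethyl would still stay level with compound 3.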